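This account rests on a few compounds, and the source may have more. Where it says the series, first, only, none or still open, it means among the compounds named here.

Compound 1 `O=C(Nc1ccc(F)c(-c2nc3ccccc3o2)c1)c1cc([N+](=O)[O-])ccc1Cl`: > 25000 nM
Compound 2 `O=C(O)COc1cc(Cl)c(C(=O)Nc2cccc(-c3nc4ccccc4s3)c2)cc1[N+](=O)[O-]`: > 25000 nM
Compound 3 `O=C(Nc1ccc(F)c(-c2nc3ccccc3s2)c1)c1cc([N+](=O)[O-])ccc1Cl`: > 25000 nM

All three results come from an ADME assay on Raji cells (Homo sapiens) for cytotoxicity, with a stated time of 72 h; a lower number here means that less compound is needed, a higher number that more compound is needed for the effect. In this assay, compound 3 gives > 25000 nM, which is a limit of the assay and not a number. Compound 3 cannot be ranked against the other two compounds, as the data show (the limit of > 25000 nM in this assay, at which 3 of the 3 values shown sit).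

Compound 4 `O=C(Nc1cccc(-c2nc3ccccc3s2)c1)c1cc([N+](=O)[O-])ccc1Cl` differs from compound 3 by hydrogen in place of fluoro on an aromatic carbon, ortho to a 1,3-benzothiazol-2-yl group: hydrogen in place of fluoro on an aromatic carbon. The one measured step among these compounds is a step that the two limits leave unreadable from compound 1 to compound 3. It concerns another part of the structure and offers no size to carry over. Compound 2 also has no fluoro on that ring, though it differs elsewhere too, and it gives > 25000 nM, again a limit. On that basis, no step beyond the usual scatter is expected, and no direction can be favoured. The expected step is a number no higher from compound 3 to compound 4 (the limit leaves the size open). Compound 4 is estimated at 25000 nM, with an expected range of 10000 nM to 60000 nM.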

Compound 4, half-maximal effective concentration: > 27000 nM
Compound 4: only a limit was reported (the forecaster's own chance of this, stated with the estimate: 85%); middle value at least 1.0-fold (0.03 log units) away from the limit.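

In this assay compound 4 gives > 27000 nM, a limit and not a number, so the steps to it from compound 2 and compound 3 cannot be read: the limit of > 27000 nM in this assay, at which 1 of the 4 values shown sits. The compounds shown leave open whether any of these structural changes alters the result, as none of them has a measured number.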